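Methylsulfonyl for acetyl on the amine nitrogen

The source may hold more compounds than are shown below. What is called first, only, known or untested is meant among the compounds shown, and "the series" means these compounds.

Measured so far:
compound 1, `CCCCc1ccc(CNS(C)(=O)=O)c(=O)n1Cc1ccc(-c2ccccc2-c2nn[nH]n2)cc1`, 54.8%
compound 2, `CCCCc1ccc(CN(Cc2ccccc2)C(C)=O)c(=O)n1Cc1ccc(-c2ccccc2-c2nn[nH]n2)cc1`, 76.3%

Among the measured compounds shown here, in a functional assay on the whole organism (artery) for inhibition, with Rattus norvegicus as the target, at a dose of 3 mg/kg by the intraduodenal route (a lower number here means less inhibition, a higher number more inhibition at the dose given (going by the name of the read-out)), compound 2 stands highest of the two numbers with 76.3%; the only step, a number 21.5 percentage points higher from compound 1 to compound 2 (beyond the scatter), changes two things at once, the entering benzyl and the exchange of methanesulfonyl for acetyl. Compound 3, `CCCCc1ccc(CN(Cc2ccccc2)S(C)(=O)=O)c(=O)n1Cc1ccc(-c2ccccc2-c2nn[nH]n2)cc1`, differs from compound 2 by methylsulfonyl in place of acetyl on an amine nitrogen. For the measured compounds named here, no measured step isolates this exchange, so the only guide is that compound 1, which carries the methanesulfonyl, gives 54.8%. A step of a number 10.3 percentage points lower from compound 2 to compound 3 (beyond the scatter) is expected, downward but not certainly beyond the scatter. Compound 3 is estimated at 66%, from 48% to 84%.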

Compound 3, a percentage reported as inhibition, in the whole organism at one dose (the size of the read-out at that dose, not a potency): 41.2%
Beside the measured number, compound 3's estimate is 24.8 percentage points above it, outside the stated range (below it).
By their numbers in this assay, from the lowest: compound 3; then compound 1; then compound 2.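

Methylsulfonyl in place of acetyl on an amine nitrogen can now be read alone in this assay, and it gives a number 35.1 percentage points lower from compound 2 to compound 3 (beyond the scatter). With methylsulfonyl held on the nitrogen, benzyl in place of hydrogen gives a number 13.6 percentage points lower from compound 1 to compound 3 (beyond the scatter), so benzyl alone does not account for the higher number of compound 2. The data give no reason for either step.

Still open, going by these compounds, is whether acetyl keeps its advantage on the nitrogen without benzyl. Also open, on these data alone, is how a propionyl or a urea on this nitrogen would compare.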